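This account rests on a few compounds, and the source may have more. Where it says the series, first, only, none or still open, it means among the compounds named here.

Compound 1 `N#Cc1cnc(NCc2cnccc2C(F)(F)F)cc1N[C@H]1C[C@@H](O)C1` gives 500 nM in an assay on isolated protein for inhibition of protein kinase C theta type (Homo sapiens), read by TR-FRET, with a stated time of 2 h; on this read-out higher numbers stand for weaker inhibition and lower numbers for stronger inhibition.
Compound 2 `N#Cc1cnc(NCc2cnccc2C(F)(F)F)cc1NC[C@H]1C[C@H](O)C1` gives 700 nM in this assay.

Compound 1 holds the lower of the two numbers, but the step of a 1.4-fold higher number from compound 1 to compound 2 (0.15 log units; within the scatter) lies within the scatter, so the two cannot be ordered. Compound 3 `N#Cc1cnc(NCc2cnccc2C(F)(F)F)cc1NCCC1CCOCC1` differs from compound 1 in that (2-(oxan-4-yl)ethyl in place of 3-hydroxycyclobutyl on a nitrogen on an aromatic ring). Going by the values given here, the only measured step, a 1.4-fold higher number from compound 1 to compound 2 (0.15 log units; within the scatter), bears on this loosely: it puts (3-hydroxycyclobutyl)methyl in place of 3-hydroxycyclobutyl on the same nitrogen and changes little. The change to compound 3 is larger, so a step in this assay beyond the scatter toward a higher number is expected, estimated as a 2.4-fold higher number from compound 1 to compound 3 (0.38 log units; beyond the scatter). Compound 3 is thus expected at 1200 nM, within 350 nM to 4000 nM.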

Compound 3, half-maximal inhibitory concentration: 1200 nM
Compound 3: the middle estimate sits on the measured number at the digits printed; measured number inside the range.
By their numbers in this assay, from the lowest: compounds 1, 2 and 3 (each within the scatter of the next, the first and the last beyond it).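

Going by these compounds alone, on the nitrogen on an aromatic ring, 2-(oxan-4-yl)ethyl in place of 3-hydroxycyclobutyl gives the first step beyond the scatter in this assay (a 2.4-fold higher number from compound 1 to compound 3 (0.38 log units; beyond the scatter)), a modest one. The other step to compound 3 stays within the scatter (a 1.7-fold higher number from compound 2 to compound 3 (0.23 log units; within the scatter)), so this position tolerates a six-membered ring with no hydrogen-bond donor without a large loss. Nothing available explains the step.

Compound 3 changes the ring, the chain and the donor count at once, so the share of each stays unresolved. Going by these compounds, an amine or a carboxylic acid in place of the hydroxyl of the 3-hydroxycyclobutyl group also remains open.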